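Swapping the Nitrogen Substituent in a Flavone-Like Core

The compounds below may be only part of what the source reports. "The series", "measured", "known", "first", "only" and "open" are said of these compounds alone.

Measured so far:
Compound 1 `COc1ccc(-c2cc(=O)c3c(OC)cc(OC)cc3n2Cc2ccccc2)cc1`: in a functional assay on HepG2 cells (Homo sapiens) for antiproliferative activity, with a stated time of 72 h (a lower number here means that less compound is needed, a higher number that more compound is needed for the effect), compound 1 gives > 17300 nM, which is a limit of the assay and not a number.
Compound 2 `COc1ccc(-c2[nH]c3cc(OC)cc(OC)c3c(=O)c2I)cc1`: in this assay compound 2 gives > 86200 nM, again a limit of the assay.
Compound 3 `COc1ccc(-c2c(I)c(=O)c3c(OC)cc(OC)cc3n2S(=O)(=O)c2ccc(OC)cc2)cc1`: in this assay compound 3 gives > 17300 nM, also a limit of the assay.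

Going by the values given here, compound 1 therefore stands only at a limit, and the two further values shown are limits as well; no compound here has a measured number. Compound 4 `COc1ccc(-c2cc(=O)c3c(OC)cc(OC)cc3n2S(=O)(=O)c2ccc(F)cc2)cc1` differs from compound 1 in one place: (4-fluorophenyl)sulfonyl in place of benzyl on an aromatic nitrogen. Among the compounds with values here, the one measured step that touches the same kind of change, a step that the two limits leave unreadable from compound 2 to compound 3, cannot be read in size because both ends sit at limits, and it also carries an iodine that compound 1 and compound 4 lack. Both limits, the limit of > 17300 nM in this assay, at which 2 of the 3 values shown sit, and (the limit of > 86200 nM in this assay, at which 1 of the 3 values shown sits), point the same way: none of the shown compounds reached a measurable effect. On that basis the expected outcome for compound 4 is again a limit rather than a number, with the step that the limit leaves unreadable from compound 1 to compound 4 expected to stay within the scatter. For compound 4 the estimate is 30000 nM, in the range 10000 nM to 100000 nM.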

Compound 4, half-maximal effective concentration: > 65500 nM
Compound 4: only a limit was reported (the forecaster's own chance of this, stated with the estimate: 80%); at least 2.1-fold (0.33 log units) between middle value and limit.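

Compound 1 and compound 4 both stand only at limits and not at numbers, so the size of the step from benzyl to (4-fluorophenyl)sulfonyl on the aromatic nitrogen cannot be read. The compounds shown leave open whether any group at that place on the shared core gives a measured number in this assay rather than a limit.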